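Difluoropiperidine in place of piperidine on the chloro analogue

The source may report more compounds than this note shows. Statements on the series, on what has been measured and on what is new or still open speak of the compounds shown alone.

Of the compounds shown here, three have been measured. In an assay on isolated protein for inhibition of protein deacetylase HDAC6 (Homo sapiens), tested at 0.5 uM (a higher number here means more inhibition at the concentration tested (going by the name of the read-out), a lower number less inhibition), compound 1 `O=C(NO)c1ccc(-c2nc(N3CCCCC3)c3ccccc3n2)cc1` gives 66.4%; compound 2 `COc1cc(OC)c2c(N3CCCCC3)nc(-c3ccc(C(=O)NO)cc3)nc2c1` gives 62.5%; compound 3 `O=C(NO)c1ccc(-c2nc(N3CCCCC3)c3ccc(Cl)cc3n2)cc1` gives 59.6%. Compound 3 stands lowest of the three numbers, but its nearest neighbour compound 2 and its furthest neighbour compound 1 both lie within the scatter of it, so no order among the three can be read. For the measured compounds named here, the one step between measured compounds that differ in a single place, a number 6.8 percentage points lower from compound 1 to compound 3 (within the scatter), is within the scatter.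

Compound 4 `O=C(NO)c1ccc(-c2nc(N3CCC(F)(F)CC3)c3ccc(Cl)cc3n2)cc1` differs from compound 3 by 4,4-difluoropiperidin-1-yl in place of piperidin-1-yl on an aromatic carbon. Going by the values given here, no measured step touches the piperidin-1-yl group; the only measured step concerns the chloro substituent, and it was within the scatter. There is thus no basis for expecting a change beyond the scatter in this assay in either direction, and the estimate for compound 4 is 58%, expected between 44% and 72%. The expected step is a number 1.6 percentage points lower from compound 3 to compound 4 (within the scatter), within the scatter.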

Compound 4, a percentage reported as inhibition, at one concentration (the size of the read-out at that concentration, not a potency): 64.6%
The estimate for compound 4 lay 6.6 percentage points below the measured number; the range from low to high includes it.
By their numbers in this assay, from the lowest: compounds 3, 2, 4 and 1 (each within the scatter of the next).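

In this assay, for the compounds shown here, 4,4-difluoropiperidin-1-yl in place of piperidin-1-yl on the aromatic carbon next to the ring nitrogen gives a number 5 percentage points higher from compound 3 to compound 4 (within the scatter), the only measured step at this position. Going by these compounds alone, this position therefore accepts the two fluorine atoms on the six-membered ring without a change that can be read, and the series so far shows no sensitivity to this replacement. Nothing measured on these compounds accounts for the step or bears on it beyond the read-out itself.

Still open, going by these compounds, is whether an amine of another kind at this position, such as morpholin-4-yl, 4-methylpiperazin-1-yl or open-chain dimethylamino, would give a step beyond the scatter. Also open, on these data alone, is whether the same replacement behaves alike on the core of compound 1, which lacks the chloro substituent.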